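The source may report more compounds than this note shows. Statements on the series, on what has been measured and on what is new or still open speak of the compounds shown alone.

Compound 1 `COc1cccc(CNCCCNc2ccnc3cc(C4CCCCC4)ccc23)c1O`: in an ADME assay for permeability, using PAMPA, with a stated time of 30 min, at pH 7.4 (on this read-out higher numbers stand for higher permeability and lower numbers for lower permeability), compound 1 gives 23 10^-6 cm/s
Compound 2 `Fc1ccc(Oc2ccc3c(NCCCNCc4ccco4)ccnc3c2)cc1`: compound 2 gives 317 10^-6 cm/s
Compound 3 `COc1ccccc1Oc1ccc2c(NCCCNCc3ccco3)ccnc2c1`: compound 3 gives 317 10^-6 cm/s

Compound 3 stands level with compound 2 at the digits shown, and together they hold the highest of the three numbers in this assay; compound 1 sits furthest away, at a markedly lower number. Among the measured compounds shown here, the only single-change step among the measured compounds, no change at the digits printed from compound 2 to compound 3 (within the scatter), swaps one aryl ether group for another and leaves the read-out unchanged within the scatter.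

Compound 4 `c1coc(CNCCCNc2ccnc3cc(C4CCCCC4)ccc23)c1` is not yet measured. The step from compound 3 to compound 4 is cyclohexyl in place of 2-methoxyphenoxy on an aromatic carbon on the core the three measured compounds share. For the measured compounds named here, no measured step bears directly on this change: the step from compound 2 to compound 3 alters the aryl ether rather than removing it, and compound 1, which carries the cyclohexyl group, differs from compound 3 in a second place as well, so its value and that of compound 3 show only that a cyclohexyl-bearing compound has so far sat far lower. On that basis compound 4 is expected to land somewhere between those two values, with the step of a 2.6-fold lower number from compound 3 to compound 4 (0.42 log units; beyond the scatter) expected to go downward but with wide uncertainty. Compound 4 is estimated at 120 10^-6 cm/s, within a range of 30 10^-6 cm/s to 350 10^-6 cm/s.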

Compound 4, apparent permeability: 23 10^-6 cm/s
The estimate for compound 4 lay 5.2-fold (0.72 log units) above the measured number, and the stated range ends above it.
By their numbers in this assay, from the lowest: compounds 1 and 4 (each within the scatter of the next); then compounds 2 and 3 (each within the scatter of the next).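

In this assay, the change on the aromatic carbon can now be read on its own: cyclohexyl in place of 2-methoxyphenoxy gives a 14-fold lower number from compound 3 to compound 4 (1.14 log units; beyond the scatter) and cyclohexyl in place of 4-fluorophenoxy gives a 14-fold lower number from compound 2 to compound 4 (1.14 log units; beyond the scatter), so the two aryl ethers, already level with each other, lose the same amount to this one replacement. The other place, the saturated chain carbon bound to the amine nitrogen, behaves differently with cyclohexyl on the core, since furan-2-yl in place of 2-hydroxy-3-methoxyphenyl gives no change at the digits printed from compound 1 to compound 4 (within the scatter) and the read-out stays within the scatter. The wide gap between compound 1 and compound 3, which earlier mixed two changes, therefore goes with the group on the aromatic carbon in these compounds and not with the group on the chain.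

Nothing at hand explains why the number falls at this position. Going by these compounds, it remains open whether phenyl or cyclohexyloxy on that aromatic carbon would stay with the aryl ethers or with cyclohexyl, and whether 2-hydroxy-3-methoxyphenyl on the chain would be just as silent with an aryl ether on the core.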